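Replacing Methylamino with Trifluoromethyl on the Aryl Ring

A few compounds are considered here, and "the series" means these few. Any claim that something is new, unique, unknown or untested is made for them only; others in the source may bear on it.

The measured compounds and their numbers:
compound 1, `CC(C)n1nc2c(c1-c1ccccc1)CCNCC2`, 530 nM
compound 2, `CC(C)n1nc2c(c1-c1ccc(F)cc1)CCNCC2`, 170 nM
compound 3, `CNc1ccc(-c2c3c(nn2C(C)C)CCNCC3)cc1`, 16 nM

In an ADME assay on membranes from Cortex for displacement of a labelled ligand from Adrenergic receptor alpha-1 (Rattus norvegicus), read by radioligand binding, with a stated time of 60 min (on this read-out higher numbers stand for weaker inhibition and lower numbers for stronger inhibition), compound 3 gives the lowest number of the three: compound 2 sits an 11-fold lower number from compound 2 to compound 3 (1.03 log units; beyond the scatter) away and compound 1 a 33-fold lower number from compound 1 to compound 3 (1.52 log units; beyond the scatter) away, both differences beyond the scatter. Compound 4, `CC(C)n1nc2c(c1-c1ccc(C(F)(F)F)cc1)CCNCC2`, has not been measured. It differs from compound 3 by trifluoromethyl in place of methylamino on an aromatic carbon, at the place described as an aromatic carbon of a six-membered aromatic ring of carbon only, para to a large group.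

Going by the values given here, the steps that bear on this change all lead into compound 3: a 33-fold lower number from compound 1 to compound 3 (1.52 log units; beyond the scatter) and an 11-fold lower number from compound 2 to compound 3 (1.03 log units; beyond the scatter), with a 3.1-fold lower number from compound 1 to compound 2 (0.49 log units; beyond the scatter) showing that fluoro alone moved the number only modestly. Among the compounds with values here, compound 4 carries neither methylamino nor fluoro but trifluoromethyl, for which no step is available, so the expectation rests on the two substituted compounds 1 and 2 as the nearer comparators. Compound 4 is therefore expected to give a higher number than compound 3 in this assay, a step of roughly a 16-fold higher number from compound 3 to compound 4 (1.19 log units; beyond the scatter), with an estimate of 250 nM in a range from 60 nM to 1000 nM.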

Compound 4, inhibition constant: 130 nM
For compound 4 the middle estimate is 1.9-fold (0.28 log units) above the measured one; the measured number falls inside the stated range.
By their numbers in this assay, from the lowest: compound 3; then compounds 4 and 2 (each within the scatter of the next); then compound 1.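

In this assay, the large drop in the number seen with methylamino at this place does not carry over to trifluoromethyl, as the exchange gives an 8.1-fold higher number from compound 3 to compound 4 (0.91 log units; beyond the scatter). Trifluoromethyl cannot be told apart from fluoro here, with a 1.3-fold lower number from compound 2 to compound 4 (0.12 log units; within the scatter), yet it remains clearly separated from hydrogen, with a 4.1-fold lower number from compound 1 to compound 4 (0.61 log units; beyond the scatter), so among the groups shown at this place, methylamino alone reaches the low range of compound 3. Nothing measured here accounts for this difference between the groups.

Going by these compounds, whether the low number belongs to methylamino alone or extends to a plain amine, a dimethylamino group or a methoxy group at this place remains open. Also open, on these data alone, is whether the same ranking would hold for other groups on the shared core.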